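The compounds below may be only part of what the source reports. "The series", "measured", "known", "first", "only" and "open" are said of these compounds alone.

Measured compounds:
- Compound 1, `Cn1c(COc2cccc(C(=O)O)c2)nc2ccc(Oc3cccc(Cl)n3)cc21`: 7.7 ug/mL
- Compound 2, `Cc1ccnc(Oc2ccc3nc(COc4cccc(C(=O)O)c4)n(C)c3c2)c1`: 33 ug/mL

Both compounds were measured in a physicochemical assay for solubility, read by HPLC, measured as thermodynamic solubility, with a stated time of 4 h, at pH 6.8; a lower number here means a less soluble compound, a higher number a more soluble compound. Among the two numbers, compound 2 stands highest, and the one step that connects them is a 4.3-fold higher number from compound 1 to compound 2 (0.63 log units; beyond the scatter). Compound 3, `Cn1c(COc2cccc(C(=O)O)c2)nc2ccc(Oc3ccc(F)cn3)cc21`, has not yet been measured in this assay. It differs from compound 2 in one place: 5-fluoropyridin-2-yl in place of 4-methylpyridin-2-yl on an oxygen on an aromatic ring. Going by the values given here, the only measured step that bears on this change is the one from compound 1 to compound 2, where swapping one substituted pyridinyl group for another on the same oxygen gave a modest rise beyond the scatter. Compound 3 carries a halogen on its pyridinyl group, as compound 1 does, rather than the methyl of compound 2. Compound 3 is therefore expected to give 15 ug/mL, within a range of 5 ug/mL to 45 ug/mL. That expectation corresponds to a step of a 2.2-fold lower number from compound 2 to compound 3 (0.34 log units; beyond the scatter), a decrease of uncertain size that may or may not exceed the scatter.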

Compound 3, solubility: 79 ug/mL
For compound 3 the middle estimate is 5.3-fold (0.72 log units) below the measured one; the whole stated range lies below it.
By their numbers in this assay, from the lowest: compound 1; then compound 2; then compound 3.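

On an oxygen on an aromatic ring, the pyridinyl group matters more than the opening pair suggested: in this assay, 5-fluoropyridin-2-yl in place of 4-methylpyridin-2-yl gives a 2.4-fold higher number from compound 2 to compound 3 (0.38 log units; beyond the scatter), while 5-fluoropyridin-2-yl in place of 6-chloropyridin-2-yl gives a 10-fold higher number from compound 1 to compound 3 (1.01 log units; beyond the scatter). Compound 1 and compound 3 both carry a halogen on this group, yet they stand at opposite ends of the three numbers, so having a halogen there does not by itself set a low number. No measurement shown explains these differences.

The compounds shown leave open whether the kind of halogen or its place on the group matters more, since 6-chloropyridin-2-yl and 5-fluoropyridin-2-yl differ in both. Going by these compounds, how a pyridinyl group carrying an amine or a methoxy group would compare at this oxygen also remains open.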